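Swapping an Amide for a Sulfonamide on a Dopamine Ligand

This account rests on a few compounds, and the source may have more. Where it says the series, first, only, none or still open, it means among the compounds named here.

Of the compounds shown here, three sharing one core have been measured in an assay on brain for displacement of a labelled ligand from D(3) dopamine receptor (Rattus norvegicus); a lower number here means a stronger inhibitor, a higher number a weaker inhibitor. Compound 1 `CCCN(CC[C@H]1CC[C@H](NC(=O)/C=C/c2ccc(Cl)cc2)CC1)[C@H]1CCc2nc(N)sc2C1` gives 2.5 nM, which places it second highest of the three numbers. Compound 3 `CCCN(CC[C@H]1CC[C@H](NC(=O)c2ccccc2-n2cccn2)CC1)[C@H]1CCc2nc(N)sc2C1` gives 2 nM, and the step of a 1.3-fold lower number from compound 1 to compound 3 (0.10 log units; within the scatter) is within the scatter. Compound 2 `CCCN(CC[C@H]1CC[C@H](NC(=O)/C=C/c2cccc(OC)c2)CC1)[C@H]1CCc2nc(N)sc2C1` gives 9.3 nM, and the step of a 3.7-fold higher number from compound 1 to compound 2 (0.57 log units; beyond the scatter) is beyond it, as is a 4.7-fold lower number from compound 2 to compound 3 (0.67 log units; beyond the scatter).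

Compound 4 `CCCN(CC[C@H]1CC[C@H](NS(=O)(=O)c2ccc(OC)cc2)CC1)[C@H]1CCc2nc(N)sc2C1` has not yet been measured. It differs from compound 1 in one place: (4-methoxyphenyl)sulfonyl in place of (2-(4-chlorophenyl)ethenyl)carbonyl on an amine nitrogen. Going by the values given here, none of the measured steps changes the carbonyl itself; the step from compound 1 to compound 3 shows that the whole group on the carbonyl can be replaced with a number within the scatter, while the step from compound 1 to compound 2 shows that a change on the aromatic ring alone can move the number modestly. Going by these compounds, a sulfonyl in place of the carbonyl is untested here, so a modest weakening is expected rather than none. Compound 4 is expected to give 15 nM, with a range from 4 nM to 60 nM. This expectation amounts to a 6.0-fold higher number from compound 1 to compound 4 (0.78 log units; beyond the scatter).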

Compound 4, inhibition constant: 0.78 nM
For compound 4 the middle estimate is 19-fold (1.28 log units) above the measured one, outside the stated range (below it).
By their numbers in this assay, from the lowest: compound 4; then compounds 3 and 1 (each within the scatter of the next); then compound 2.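

Compound 4 shows that the amine nitrogen of the shared core need not carry a carbonyl: with (4-methoxyphenyl)sulfonyl there, binding does not weaken but improves modestly, with a 3.2-fold lower number from compound 1 to compound 4 (0.51 log units; beyond the scatter). Going by these compounds alone, the earlier compounds changed only what sits on the carbonyl, whereas this is the first result showing that the carbonyl itself can be replaced while a low number is kept. Nothing measured here explains the gain.

This single change replaces the carbonyl with a sulfonyl and also swaps the 2-(4-chlorophenyl)ethenyl part for a 4-methoxyphenyl, so the compounds shown cannot assign the gain to either part. Going by these compounds, it also remains open how the number would respond to a sulfonyl carrying a 4-chlorophenyl, a methyl or a longer alkyl chain.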